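This account rests on a few compounds, and the source may have more. Where it says the series, first, only, none or still open, it means among the compounds named here.

Measured compounds:
- compound 1 `Cn1cc(-c2cnc(N)c(Oc3ccc(C(=O)Nc4ccc(Cl)cn4)cc3)n2)cn1`: in a functional assay on LoVo cells (Homo sapiens) for inhibition, read by MTT assay, with a stated time of 72 h (on this read-out higher numbers stand for weaker inhibition and lower numbers for stronger inhibition), compound 1 gives 6160 nM
- compound 2 `Cn1cc(-c2cnc(N)c(Oc3ccc(C(=O)Nc4cc(Cl)ccn4)cc3)n2)cn1`: in this assay compound 2 gives 26600 nM

Compound 2 stands at the highest of the two numbers. For the measured compounds named here, the only measured step, a 4.3-fold higher number from compound 1 to compound 2 (0.64 log units; beyond the scatter), comes from 4-chloropyridin-2-yl in place of 5-chloropyridin-2-yl on an amide-type nitrogen, so a move of the chlorine on that ring has already produced a modest change beyond the scatter. Compound 3 `Cn1cc(-c2cnc(N)c(Oc3ccc(C(=O)Nc4ncccc4Cl)cc3)n2)cn1` differs from compound 2 by 3-chloropyridin-2-yl in place of 4-chloropyridin-2-yl on an amide-type nitrogen. That step bears on the present change only loosely: it shows that the chlorine's placement on the pyridin-2-yl ring matters, but it does not show which way the move to 3-chloropyridin-2-yl will go. Compound 3 is therefore expected to land near compound 2, with a wide spread allowed in both directions, as a step of a 1.3-fold lower number from compound 2 to compound 3 (0.12 log units; within the scatter). The estimate for compound 3 is 20000 nM, expected between 5000 nM and 80000 nM.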

Compound 3, half-maximal inhibitory concentration: 16500 nM
Compound 3: the middle estimate sits 1.2-fold (0.08 log units) above what was measured, within the range that was stated.
By their numbers in this assay, from the lowest: compound 1; then compounds 3 and 2 (each within the scatter of the next).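

In this assay the change to 3-chloropyridin-2-yl gives a 1.6-fold lower number from compound 2 to compound 3 (0.21 log units; within the scatter) so this placement of the chlorine cannot be told apart from 4-chloropyridin-2-yl on this read-out. Measured against 5-chloropyridin-2-yl, the same group gives a 2.7-fold higher number from compound 1 to compound 3 (0.43 log units; beyond the scatter) so both other placements now stand beyond the scatter from compound 1, which has the lowest number of the three and the strongest inhibition among them. No supporting data are available to explain this dependence on the chlorine's placement.

The compounds shown leave open whether the number of compound 1 depends on chlorine itself, which a plain pyridin-2-yl or a 5-fluoropyridin-2-yl on the amide-type nitrogen would address. They also leave open how a 6-chloropyridin-2-yl would compare with the three placements shown.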